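This account rests on a few compounds, and the source may have more. Where it says the series, first, only, none or still open, it means among the compounds named here.

Going by the values given here, compound 1 `N[C@@H](C(=O)Nc1cc2cc[nH]c(=O)c2cc1Cl)C1CCCCC1` sits second highest of the three numbers measured so far: in an assay on isolated protein for inhibition of Rho-associated protein kinase 2 (Homo sapiens) (a higher number here means a weaker inhibitor, a lower number a stronger inhibitor), compound 1 gives 400 nM. Its nearest neighbour is compound 2 `CN(C)[C@H]1CC[C@@H](C(=O)Nc2cc3cc[nH]c(=O)c3cc2Cl)CC1`, which gives 1000 nM, and the furthest is compound 3 `O=C(Nc1cc2cc[nH]c(=O)c2cc1Cl)[C@H]1CCCN1`, which gives 130 nM. Compound 4 `N[C@H](C(=O)Nc1cc2cc[nH]c(=O)c2cc1Cl)C1CCCCC1` is built from compound 1 by a single change: the two compounds have the same atoms and bonds and differ only in configuration as drawn: 1 of 1 stereo elements differ; a stereocentre at a saturated chain carbon is drawn R in compound 1 and S in compound 4. Among the compounds with values here, no measured pair here isolates such a change in configuration, so the size and direction of the step rest on expectation alone; a moderate step beyond the scatter, toward a lower number, is expected, leaning on compound 3 with its value of 130 nM as the only compound drawn in the other sense. Compound 4 is therefore estimated at 150 nM, with a range from 40 nM to 600 nM, an expected step of a 2.7-fold lower number from compound 1 to compound 4 (0.43 log units; beyond the scatter).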

Compound 4, half-maximal inhibitory concentration: 20 nM
The estimate for compound 4 lay 7.5-fold (0.88 log units) above the measured number, and the stated range ends above it.
By their numbers in this assay, from the lowest: compound 4; then compound 3; then compound 1; then compound 2.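

Changing the stereocentre at this saturated chain carbon from R to S gives a 20-fold lower number from compound 1 to compound 4 (1.30 log units; beyond the scatter) in this assay. The earlier compounds shown here differ from one another in more than one place, so they could not separate configuration from the rest of the structure. This large step can be assigned to configuration alone because of one structural fact: the fact that compounds 1 and 4 differ only in the configuration as drawn.

On these data alone, it remains open whether S would still give the lower number with another group on this carbon, such as a phenyl ring or a longer chain. As far as these compounds go, how configuration acts at the protein also remains unknown.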